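A Phenyl Substituent on a Core That Shows Only Limits

The source may report more compounds than this note shows. Statements on the series, on what has been measured and on what is new or still open speak of the compounds shown alone.

Measured in a functional assay for inhibition, with Homo sapiens as the target; a higher number here means a weaker inhibitor, a lower number a stronger inhibitor:
Compound 1 `CCc1nc(C)c2cnnc(SC)n12` gives a limit, > 48000 nM.
Compound 2 `CSc1nncc2c(C)nc(C)n12` gives a limit, > 48000 nM.
Compound 3 `CSc1nncc2c(C)ncn12` gives a limit, > 48000 nM.

Compound 1 therefore stands at the assay limit, where all three measured compounds sit, as the limit of > 48000 nM in this assay, at which 3 of the 3 values shown sit, records. The steps between them, a step that the two limits leave unreadable from compound 1 to compound 2, a step that the two limits leave unreadable from compound 1 to compound 3 and a step that the two limits leave unreadable from compound 2 to compound 3, cannot be read in size or direction. Compound 4 `CCc1nc(C)c2c(-c3ccccc3)nnc(SC)n12` arises from compound 1 through (phenyl in place of hydrogen on an aromatic carbon). Among the measured compounds shown here, none of the measured steps touches a phenyl group, and none yields a readable size, so no measured step bears on this change. The expected step of an at least 1.6-fold lower number from compound 1 to compound 4 (0.20 log units; that floor lies within the scatter) is set close to no change, with a wide range. Compound 4 is estimated at 30000 nM, between 5000 nM and 100000 nM, with a substantial chance that only a limit is reported.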

Compound 4, half-maximal inhibitory concentration: > 48000 nM
Compound 4 was reported as a limit (the forecaster's own chance of this, stated with the estimate: 60%); middle value at least 1.6-fold (0.20 log units) from the limit.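

No new step can be read between compound 1 and compound 4 in this assay, where every compound shown gives only a limit: the limit of > 48000 nM in this assay, at which 4 of the 4 values shown sit. The compounds shown leave open whether phenyl in place of hydrogen, or any other change to the shared core, alters inhibition at all.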